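The source may report more compounds than this note shows. Statements on the series, on what has been measured and on what is new or still open speak of the compounds shown alone.

Within the data shown here, compound 1 `O=C(/C(=C\c1ccc(I)cc1)S(=O)(=O)c1ccc(Br)cc1)c1ccc(Br)cc1` is the only member of this set with a numerical result: in a functional assay on DU-145 cells (Homo sapiens) for inhibition, read by trypan blue exclusion, with a stated time of 96 h (on this read-out lower numbers stand for stronger inhibition of growth and higher numbers for weaker inhibition of growth), compound 1 gives 1000 nM. The other measured member, compound 2 `O=C(/C(=C\c1ccc(O)c([N+](=O)[O-])c1)SCc1ccc(Br)cc1)C1CCNC1`, is represented by a limit of the assay rather than a number. In this assay compound 2 gives > 100000 nM, which is a limit. Compound 2 therefore accounts for (the limit of > 100000 nM in this assay, at which 1 of the 2 values shown sits). Compound 1 and compound 2 differ in many places at once, so their two values can only be set side by side, not read as a single step.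

Compound 3 `O=C(/C(=C\c1c[nH]c2ccccc12)S(=O)(=O)c1ccc(Br)cc1)c1ccc(Br)cc1` remains to be measured. It differs from compound 1 by 1H-indol-3-yl in place of 4-iodophenyl on a double-bonded chain carbon bound to a double-bonded chain carbon. Among the measured compounds shown here, no measured pair in this set follows that change alone, so there is nothing here to fix its size. The change keeps the shared core of compound 1 intact and exchanges only the aryl group at the end of the chain, so in this assay no step beyond the usual scatter is expected, in either direction. For compound 3 the expected value is 800 nM, with a range from 250 nM to 3000 nM. That estimate means an expected step of a 1.3-fold lower number from compound 1 to compound 3 (0.10 log units; within the scatter).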

Compound 3, concentration for 50% growth inhibition: 25000 nM
Estimate against measurement, compound 3: 31-fold (1.49 log units) below; measured number above the stated range.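

In this assay, the aryl group at the end of the chain proves to be far from a neutral exchange: 1H-indol-3-yl in place of 4-iodophenyl gives a 25-fold higher number from compound 1 to compound 3 (1.40 log units; beyond the scatter). Among these compounds, this is the first step in the set that can be read as a single change, and it shows that this place alone, on a double-bonded chain carbon bound to a double-bonded chain carbon, can move the number well beyond the usual scatter while the shared core of compound 1 stays intact. The entering group brings a second ring and a hydrogen-bond donor, and the iodine leaves, but nothing measured here separates these differences or accounts for the step.

The compounds shown leave open which of these differences carries the step, since only one replacement at this place can be followed. A 1-methyl-1H-indol-3-yl group at the same place would bear on the role of the hydrogen on the ring nitrogen, and a plain phenyl or a 4-bromophenyl group would bear on the role of the iodine.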